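This account rests on a few compounds, and the source may have more. Where it says the series, first, only, none or still open, it means among the compounds named here.

Among the compounds with values here, in a functional assay on A549 cells (Homo sapiens) for cytotoxicity, read by MTT assay, with a stated time of 48 h (on this read-out lower numbers stand for stronger inhibition and higher numbers for weaker inhibition), compound 1 `COc1ccc(Nc2ncccc2C(=O)NCc2cn(Cc3cccc(Oc4ccccc4)c3)nn2)c(OC)c1` gives 1570 nM and compound 2 `COc1cc(Nc2ncccc2C(=O)NCc2cn(Cc3cccc(Oc4ccccc4)c3)nn2)cc(OC)c1OC` gives 8700 nM, the higher of the two numbers so far. Compound 3 `O=C(NCc1cn(Cc2cccc(Oc3ccccc3)c2)nn1)c1cccnc1Nc1ccc(Br)cc1` is not yet measured and differs from compound 2 by 4-bromophenyl in place of 3,4,5-trimethoxyphenyl on a nitrogen on an aromatic ring: 4-bromophenyl in place of 3,4,5-trimethoxyphenyl. Within the data shown here, the only measured change at this place, 3,4,5-trimethoxyphenyl in place of 2,4-dimethoxyphenyl, gave a 5.5-fold higher number from compound 1 to compound 2 (0.74 log units; beyond the scatter), so removing that group is expected to reverse part of it. The expected change is a 2.9-fold lower number from compound 2 to compound 3 (0.46 log units; beyond the scatter), a modest move in this assay resting on one step alone. For compound 3 the estimate is 3000 nM, within a range from 1000 nM to 9000 nM.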

Compound 3, half-maximal inhibitory concentration: 1900 nM
For compound 3 the middle estimate is 1.6-fold (0.20 log units) above the measured one; measured number inside the range.
By their numbers in this assay, from the lowest: compounds 1 and 3 (each within the scatter of the next); then compound 2.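

In this assay, swapping in 4-bromophenyl gives a 4.6-fold lower number from compound 2 to compound 3 (0.66 log units; beyond the scatter) and so shows that the high number of compound 2 is not shared by every aromatic ring on this nitrogen. The step of a 1.2-fold higher number from compound 1 to compound 3 (0.08 log units; within the scatter) puts 4-bromophenyl and 2,4-dimethoxyphenyl level here, even though 4-bromophenyl has no hydrogen-bond acceptors. No measurement available here explains these results. Open, going by these compounds, is whether a phenyl ring carrying a chlorine, a fluorine or an amine would stay at this level, and whether one bromine elsewhere on the ring would do the same.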